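The compounds below may be only part of what the source reports. "The series", "measured", "known", "first", "only" and "open" are said of these compounds alone.

In a functional assay on PANC-1 cells (Homo sapiens) for inhibition, read by MTT assay, with a stated time of 24 h (a higher number here means a weaker inhibitor, a lower number a stronger inhibitor), compound 1 (`CC1(C)[C@H]2CC[C@]1(C)N(Cc1cn(-c3ccccc3F)nn1)C(=O)C2`) gives 150 nM, compound 2 (`CC1(C)[C@H]2CC[C@]1(C)N(Cc1cn(-c3ccccc3Cl)nn1)C(=O)C2`) gives 270 nM and compound 3 (`CC1(C)[C@H]2CC[C@]1(C)N(Cc1cn(-c3cccc(Cl)c3)nn1)C(=O)C2`) gives 260 nM. Compound 3 is second highest of the three numbers, but it lies within the scatter of both others: a 1.0-fold lower number from compound 2 to compound 3 (0.02 log units; within the scatter) and a 1.7-fold higher number from compound 1 to compound 3 (0.24 log units; within the scatter).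

The next change leads to compound 4 (`COc1ccccc1-n1cc(CN2C(=O)C[C@@H]3CC[C@@]2(C)C3(C)C)nn1`), with 2-methoxyphenyl in place of 3-chlorophenyl on an aromatic nitrogen. The measured steps that bear on it all alter the same aryl group. Chloro in place of fluoro gives a 1.8-fold higher number from compound 1 to compound 2 (0.26 log units; within the scatter), and the other two steps are those already given for compound 3. Among the compounds with values here, none leaves the scatter, although no compound with a methoxy group has been measured, so this evidence is indirect.

The expected change in this assay is therefore no step beyond the scatter and no firm direction, with an estimated 1.2-fold lower number from compound 3 to compound 4 (0.07 log units; within the scatter). Compound 4 is expected at 220 nM, with an estimated range of 90 nM to 550 nM.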

Compound 4, half-maximal inhibitory concentration: 120 nM
Beside the measured number, compound 4's estimate is 1.8-fold (0.26 log units) above it; measured number inside the range.
By their numbers in this assay, from the lowest: compounds 4, 1, 3 and 2 (each within the scatter of the next, the first and the last beyond it).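

In this assay, within the data shown here, 2-methoxyphenyl on the aromatic nitrogen gives the first steps at this position that leave the scatter, both modest and both against a chlorinated aryl group (a 2.2-fold lower number from compound 3 to compound 4 (0.34 log units; beyond the scatter)) (a 2.3-fold lower number from compound 2 to compound 4 (0.35 log units; beyond the scatter)). Methoxy in place of fluoro does not separate compound 4 from compound 1 (a 1.3-fold lower number from compound 1 to compound 4 (0.10 log units; within the scatter)), so the change of substituent does not set compound 4 apart from every compound shown. No measurement shown bears on what lies behind these steps.

Open, as far as these compounds go, is whether an amine, a carboxylic acid or an ethoxy group on the aryl ring would stay with compound 4 and compound 1 or with the two chloro compounds. Also open, from the compounds shown here alone, is whether methoxy would give the same steps in the place that chloro holds in the 3-chlorophenyl group of compound 3.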